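A few compounds are considered here, and "the series" means these few. Any claim that something is new, unique, unknown or untested is made for them only; others in the source may bear on it.

Compound 3 `C=CCOc1ccccc1C1CC(=O)c2ccccc2O1` is the starting point of this step. Going by the values given here, in a functional assay on RAW264.7 cells (Mus musculus) for inhibition, read by immunoassay, with a stated time of 12 h, tested at 30 uM (a higher number here means more inhibition at the concentration tested (going by the name of the read-out), a lower number less inhibition), compound 3 gives 49.3%, which places it second highest among the three compounds measured so far. Its nearest neighbour is compound 1 `CCCOc1ccccc1C1CC(=O)c2ccccc2O1`, which in this assay gives 45.7%; the step of a number 3.6 percentage points higher from compound 1 to compound 3 (within the scatter) is small. Far above both stands compound 2 `CC(C)c1ccc(COc2ccccc2C2CC(=O)c3ccccc3O2)cc1`, which in this assay gives 91.5%, so that the step of a number 42.2 percentage points lower from compound 2 to compound 3 (beyond the scatter) is large.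

Compound 4 `CCCCCOc1ccccc1C1CC(=O)c2ccccc2O1` has not yet been measured. It differs from compound 3 in one place: butyl in place of vinyl on a saturated chain carbon bound to an oxygen on an aromatic ring. The measured steps that bear on this are the two swaps at the same position. The swap of one small chain for another, a number 3.6 percentage points higher from compound 1 to compound 3 (within the scatter), stayed within the scatter, whereas bringing in 4-isopropylphenyl, a number 45.8 percentage points higher from compound 1 to compound 2 (beyond the scatter), made a large difference. Butyl is another small chain without a ring, so the step expected in this assay, a number 0.7 percentage points higher from compound 3 to compound 4 (within the scatter), is none beyond the scatter. Compound 4 is therefore estimated at 50%, with a range from 35% to 65%.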

Compound 4, a percentage reported as inhibition, at one concentration (the size of the read-out at that concentration, not a potency): 41.3%
For compound 4 the middle estimate is 8.7 percentage points above the measured one, within the range that was stated.
By their numbers in this assay, from the lowest: compounds 4, 1 and 3 (each within the scatter of the next); then compound 2.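

In this assay, making the open chain longer barely registers: the step, a number 4.4 percentage points lower from compound 1 to compound 4 (within the scatter), adds to the chain without moving the result beyond the scatter. The double bond also proves unnecessary among these compounds, since replacing allyloxy with pentyloxy removes it and lengthens the chain, yet the step, a number 8 percentage points lower from compound 3 to compound 4 (within the scatter), also stays within the scatter. Added chain length therefore does not reproduce the effect of the ring-bearing group, and the step, a number 50.2 percentage points lower from compound 2 to compound 4 (beyond the scatter), leaves the 4-isopropylphenyl compound alone at the top, with the three open-chain compounds together well beneath it.

No measurement here explains why the open chains behave alike or why the ring-bearing compound stands apart. Still open, from the compounds shown here alone, is whether the aromatic ring alone accounts for that gap, which a plain benzyl group in this place would test, and whether a much longer chain, or a chain ending in an amine or a carboxylic acid, would leave the result unchanged.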